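Working notes: carbamoyl for chloro in the cytotoxicity read-out

The compounds below may be only part of what the source reports. "The series", "measured", "known", "first", "only" and "open" are said of these compounds alone.

Compound 1 `Cc1cc(NC(=O)Nc2ccc(N)cc2)c2ccccc2n1`: in an ADME assay on HepG2 cells (Homo sapiens) for cytotoxicity, with a stated time of 72 h (on this read-out higher numbers stand for an effect only at larger amounts of compound and lower numbers for an effect already at smaller amounts), compound 1 reaches only the limit > 25000 nM.
Compound 2 `Cc1cc(NC(=O)Nc2ccccc2F)c2ccccc2n1`: in this assay compound 2 likewise reaches only the limit > 25000 nM.
Compound 3 `Cc1cc(NC(=O)Nc2cccc(Cl)c2)c2ccccc2n1`: in this assay compound 3 gives 19000 nM.

Among the measured compounds shown here, compound 3 holds the only number in the set; the other two values are limits, and the limit of > 25000 nM in this assay, at which 2 of the 3 values shown sit, marks where they sit. The steps into compound 3 are an at least 1.3-fold lower number from compound 1 to compound 3 (0.11 log units; that floor lies within the scatter) and an at least 1.3-fold lower number from compound 2 to compound 3 (0.11 log units; that floor lies within the scatter), both readable only as floors that lie within the scatter; a step that the two limits leave unreadable from compound 1 to compound 2 is unreadable. Compound 4 `Cc1cc(NC(=O)Nc2cccc(C(N)=O)c2)c2ccccc2n1` differs from compound 3 in one place: carbamoyl in place of chloro on an aromatic carbon. For the measured compounds named here, no measured step exchanges a chloro for a carbamoyl, so the steps above bear on it only by showing that the whole set sits at or near the limit of this assay, with no step resolved beyond the scatter. The expected step is therefore none beyond the scatter, a 1.5-fold higher number from compound 3 to compound 4 (0.17 log units; within the scatter), with a fair chance that compound 4 again returns only a limit. Compound 4 is estimated at 28000 nM, between 14000 nM and 60000 nM.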

Compound 4, half-maximal effective concentration: > 25000 nM
Compound 4 ended at the assay's limit (the forecaster's own chance of this, stated with the estimate: 55%); the middle value lies beyond the limit too.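

In this assay, carbamoyl in place of chloro on this aromatic carbon, meta to a large group, gives an at least 1.3-fold higher number from compound 3 to compound 4 (0.11 log units; that floor lies within the scatter). The earlier steps shown here exchanged the whole substituted phenyl group, whereas this one changes a single group on it: carbamoyl brings a hydrogen-bond donor and a hydrogen-bond acceptor that chloro lacks, yet no change beyond the scatter can be resolved. The true size of the step stays unknown because compound 4 reaches only a limit, not a number: the limit of > 25000 nM in this assay, at which 3 of the 4 values shown sit.

On these data alone, whether an amine or a carboxylic acid on the same aromatic carbon would give a number or again only a limit remains open. Also open, as far as these compounds go, is whether a bromo or a methyl group here would give a value close to that of compound 3.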